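The compounds below may be only part of what the source reports. "The series", "measured", "known", "first", "only" and "open" are said of these compounds alone.

Going by the values given here, compound 3 `COc1ccc2cc(C(C)c3nnc4n3N=C(c3ccc(Cl)cc3Cl)CS4)ccc2c1` gives 14000 nM in a functional assay on HCT-116 cells (Homo sapiens) for inhibition, read by sulforhodamine B assay, with a stated time of 72 h (a higher number here means a weaker inhibitor, a lower number a stronger inhibitor), the highest of the three numbers measured so far. Compound 2 `CC(c1ccc(-c2ccccc2)c(F)c1)c1nnc2n1N=C(c1ccccc1)CS2` gives 9700 nM in this assay, a gap to compound 3 that lies within the scatter. Compound 1 `CC(c1ccc(-c2ccccc2)c(F)c1)c1nnc2n1N=C(c1ccc(Cl)cc1Cl)CS2` gives 6900 nM in this assay, and its gap to compound 3 lies beyond the scatter. Compound 4 `COc1ccc2cc(C(C)c3nnc4n3N=C(c3ccc(C)cc3)CS4)ccc2c1` differs from compound 3 in one place: 4-methylphenyl in place of 2,4-dichlorophenyl on a carbon with a double bond to nitrogen. Among the compounds with values here, only one measured step bears on this change, namely a 1.4-fold higher number from compound 1 to compound 2 (0.15 log units; within the scatter), in which the 2,4-dichlorophenyl on a carbon with a double bond to nitrogen gave way to phenyl. That step stayed within the scatter, and the swap of 2,4-dichlorophenyl for 4-methylphenyl in the same place is a change of the same kind, so no step beyond the scatter is expected in this assay. The expected step is a 1.1-fold higher number from compound 3 to compound 4 (0.03 log units; within the scatter). Compound 4 is therefore estimated at 15000 nM in this assay, with a range from 6000 nM to 38000 nM.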

Compound 4, half-maximal inhibitory concentration: 10200 nM
Compound 4: the middle estimate sits 1.5-fold (0.17 log units) above what was measured, within the range that was stated.
By their numbers in this assay, from the lowest: compounds 1, 2, 4 and 3 (each within the scatter of the next, the first and the last beyond it).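

The step of a 1.4-fold lower number from compound 3 to compound 4 (0.14 log units; within the scatter) shows that a second aryl swap on the carbon with a double bond to nitrogen also leaves the number within the scatter in this assay. This time the swap was made on the core of compound 3 and not on the core of compound 1, so the earlier step of a 1.4-fold higher number from compound 1 to compound 2 (0.15 log units; within the scatter) no longer stands alone, and across these two pairs, loss of the 2,4-dichlorophenyl made no difference beyond the scatter. Why this place shows so little response cannot be said, as no measurement here speaks to a cause.

Going by these compounds, all three groups compared at this place are six-membered aromatic rings of carbon only, so what an amine or a carboxylic acid on that ring would do remains open. A longer chain in place of the methyl of the 4-methylphenyl is equally untested among the compounds shown.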